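The source may hold more compounds than are shown below. What is called first, only, known or untested is meant among the compounds shown, and "the series" means these compounds.

Measured so far:
compound 1 `COc1ccc(C2N=C(SCc3ccccc3)NC(C)=C2C(=O)Nc2ccc(F)cc2)cc1OC`: 11.8%
compound 2 `CC1=C(C(=O)Nc2ccc(F)cc2)C(c2ccc([N+](=O)[O-])cc2)N=C(SCc2ccccc2)N1`: 32.3%

In a functional assay on the whole organism (artery, strain albino) with Rattus norvegicus as the target, with a stated time of 240 min, at a dose of 10 mg/kg by the oral route (on this read-out lower numbers stand for less inhibition and higher numbers for more inhibition at the one dose given (going by the name of the read-out)), compound 1 gives 11.8% and compound 2 gives 32.3%, so compound 2 stands highest of the two numbers. For the measured compounds named here, the one measured step, a number 20.5 percentage points higher from compound 1 to compound 2 (beyond the scatter), concerns a group on a saturated ring carbon. Compound 3 `CC1=C(C(=O)Nc2ccc(F)cc2)C(c2ccc([N+](=O)[O-])cc2)N=C(SCc2ccc(F)cc2)N1` differs from compound 2 by fluoro in place of hydrogen on an aromatic carbon, sitting on an aromatic carbon of a six-membered aromatic ring of carbon only, para to a large group. Going by the values given here, no measured step bears on this kind of change, so a step of no size beyond the scatter is expected, a number 0.3 percentage points lower from compound 2 to compound 3 (within the scatter). Compound 3 is therefore estimated at 32%, within a range from 15% to 50%.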

Compound 3, a percentage reported as inhibition, in the whole organism at one dose (the size of the read-out at that dose, not a potency): 25.6%
Beside the measured number, compound 3's estimate is 6.4 percentage points above it; the measured number falls inside the stated range.
By their numbers in this assay, from the lowest: compound 1; then compounds 3 and 2 (each within the scatter of the next).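

In this assay, (4-fluorobenzyl)sulfanyl in place of benzylsulfanyl gives a number 6.7 percentage points lower from compound 2 to compound 3 (within the scatter), so a single fluoro at this aromatic carbon, para to a large group, leaves no clear mark on the read-out. For the compounds shown here, the earlier step between compound 1 and compound 2 concerned only the saturated ring carbon, so this is the first sign about the benzylsulfanyl end. No measurement here offers an explanation for this result.

Still open, on these data alone, is whether an amine or a methoxy group at this carbon would move the number beyond the scatter. As far as these compounds go, a longer chain in place of benzyl remains an equally open question.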